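The source may hold more compounds than are shown below. What is called first, only, known or untested is meant among the compounds shown, and "the series" means these compounds.

Compound 1 `CCCn1c(=O)[nH]c2nc(-c3ccc(S(=O)(=O)N4CCN(C)CC4)cc3)[nH]c2c1=O` and compound 2 `CCCn1c(=O)[nH]c2nc(-c3ccc(S(=O)(=O)N4CCN(Cc5ccc(Br)c(F)c5)CC4)cc3)[nH]c2c1=O` share one core and differ only at a saturated chain carbon bound to an amine nitrogen in a ring. In an assay on CHO cells for displacement of a labelled ligand from adenosine receptor A3 (Homo sapiens), read by scintillation counting, with a stated time of 45 min, tested at 1 uM, in the presence of a further agent that is not named here (a higher number here means more inhibition at the concentration tested (going by the name of the read-out), a lower number less inhibition), compound 1 gives 7%, while compound 2 gives 27%, the higher of the two numbers, a number 20 percentage points higher from compound 1 to compound 2 (beyond the scatter). Compound 3 `CCCn1c(=O)[nH]c2nc(-c3ccc(S(=O)(=O)N4CCN(c5ccccc5Cl)CC4)cc3)[nH]c2c1=O` carries 2-chlorophenyl in place of 4-bromo-3-fluorobenzyl on an amine nitrogen in a ring. For the measured compounds named here, only that one measured step bears on this change, and it rose when an aromatic group entered; compound 3 keeps an aromatic group, but with fewer heavy atoms. Compound 3 is therefore expected to give 20%, within a range from 5% to 40%. This estimate means an expected a number 7 percentage points lower from compound 2 to compound 3 (within the scatter).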

Compound 3, a percentage reported as inhibition, at one concentration (the size of the read-out at that concentration, not a potency): 32%
Compound 3: middle estimate off by 12 percentage points, on the low side, and the stated range covers the measured number.
By their numbers in this assay, from the lowest: compound 1; then compounds 2 and 3 (each within the scatter of the next).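

In this assay, the aromatic ring can sit directly on the amine nitrogen in the ring, without the benzyl carbon, and the two groups cannot be told apart: a number 5 percentage points higher from compound 2 to compound 3 (within the scatter). 2-Chlorophenyl also stands clear of methyl, with a number 25 percentage points higher from compound 1 to compound 3 (beyond the scatter), so two different aromatic groups now share this gain. Nothing measured here explains why they read alike.

Open, from the compounds shown here alone, is whether the gain needs an aromatic ring at all, which a cyclohexyl group or a longer chain at this nitrogen would test. Plain phenyl would show whether the chlorine plays any part.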